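The source may report more compounds than this note shows. Statements on the series, on what has been measured and on what is new or still open speak of the compounds shown alone.

The measured compounds in a functional assay on U-87MG ATCC cells for inhibition, with U-87 MG (Homo sapiens) as the target, read by MTT assay, with a stated time of 48 h; on this read-out lower numbers stand for stronger inhibition and higher numbers for weaker inhibition:

compound 1, `COc1cc(/C=N/Nc2nc(-c3cccc(Br)c3)cs2)cc(Br)c1OC`, gives 86300 nM
compound 2, `COc1cc(/C=N/Nc2nc(-c3cc(C(F)(F)F)cc(C(F)(F)F)c3)cs2)cc(Br)c1OC`, gives only a limit, > 100000 nM
compound 3, `COc1cc(/C=N/Nc2nc(-c3cccc(Br)c3)cs2)c(Br)c(Br)c1OC`, gives 27600 nM

Compound 1 and compound 3 share a core and differ in one place: bromo in place of hydrogen on an aromatic carbon. That change gave a 3.1-fold lower number from compound 1 to compound 3 (0.50 log units; beyond the scatter) in this assay, a modest but real gain in inhibition.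

Compound 2 carries a different core, and how it differs from compound 1 is not broken down here. Its value in this assay is a limit and not a number, and it sits at the limit of > 100000 nM in this assay, at which 1 of the 3 values shown sits. The unmeasured compound 4, `COc1cc(/C=N/Nc2nc(-c3cc(C(F)(F)F)cc(C(F)(F)F)c3)cs2)c(Br)c(Br)c1OC`, stands to compound 2 as compound 3 stands to compound 1: bromo in place of hydrogen on an aromatic carbon. The place of the change is described in the same words in both pairs, so it is the same change made on two cores.

Going by the values given here, whether the change will carry the same weight on the core of compound 2 is uncertain, because compound 2 is known only as a limit and the step from compound 1 to compound 3 is the single measured example. On that one example, compound 4 is expected to show a step of an at least 1.4-fold lower number from compound 2 to compound 4 (0.15 log units; that floor lies within the scatter) in this assay. Compound 4 is therefore estimated at about 70000 nM in this assay, with a range from 25000 nM to 200000 nM, and it may well again come back as a limit.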

Compound 4, half-maximal inhibitory concentration: > 100000 nM
Compound 4 ended at the assay's limit; the forecaster's own chance of this, stated with the estimate: 45%; at least 1.4-fold (0.15 log units) between middle value and limit.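

In this assay compound 4 gives > 100000 nM, a limit of the assay and not a number. Compound 2 stands at that same limit, so no step can be read between compound 2 and compound 4: the limit of > 100000 nM in this assay, at which 2 of the 4 values shown sit. The compounds shown leave open whether bromo in place of hydrogen on an aromatic carbon changes inhibition at all on the core of compound 2.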